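Swapping 2-hydroxyphenyl for propyl on a carbonyl carbon

The compounds below may be only part of what the source reports. "The series", "measured", "known", "first", "only" and "open" are said of these compounds alone.

Compound 1 `COc1ccc(-c2cnc(NC(=O)c3ccc(F)cc3)n2Cc2ccccc2)cc1`: > 100000 nM
Compound 2 `Cn1c(-c2ccccc2)cnc1NC(=O)c1ccc(F)cc1`: > 100000 nM
Compound 3 `COc1ccc(-c2cnc(NC(=O)c3ccccc3O)n2C)cc1`: > 100000 nM

All three results come from a toxicity assay on THP-1 cells (Homo sapiens) for inhibition (on this read-out lower numbers stand for higher toxicity in this test and higher numbers for lower toxicity in this test), and none of them is an exact number. Together they show (the limit of > 100000 nM in this assay, at which 3 of the 3 values shown sit). Compound 3 stands at > 100000 nM, which is a limit of the test and not a measured number.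

The next compound is compound 4 `CCCC(=O)Nc1ncc(-c2ccc(OC)cc2)n1C`, which keeps the shared core of compound 3 and changes a single group: propyl in place of 2-hydroxyphenyl on a carbonyl carbon. Put simply, propyl takes the place of 2-hydroxyphenyl on a carbonyl carbon, so a ring-bearing group gives way to a short chain with no ring.

Among the compounds with values here, no two measured compounds differ in just one place, so the data hold no direct measure of what a swap like this does. Because compound 3 gives > 100000 nM the expectation in this assay is no step beyond the usual scatter, and the most likely result is another limit. The expected change is a number no higher from compound 3 to compound 4 (the limit leaves the size open). Compound 4 is estimated at 100000 nM, with an expected range of 40000 nM to 200000 nM.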

Compound 4, half-maximal cytotoxic concentration: > 100000 nM
Compound 4 gave a limit, no number (the forecaster's own chance of this, stated with the estimate: 85%); the middle value lies on the limit itself.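

In this assay compound 4 gives > 100000 nM, which is a limit and not a measured number. Compound 3 also sits at a limit, and no step can be read between compound 3 and compound 4. The compounds shown leave open whether any change to them would give a measured number, with every value at the same limit: the limit of > 100000 nM in this assay, at which 4 of the 4 values shown sit.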